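The compounds below may be only part of what the source reports. "The series", "measured", "known", "first", "only" and "open" are said of these compounds alone.

Working notes on the series. Compound 1 `Cc1cc(-c2cc(Cl)cc(Cl)c2/C=C/[C@@H]2C[C@@H](O)CC(=O)O2)ccc1F` and compound 2 `Cc1cc(F)ccc1-c1cc(Cl)cc(Cl)c1/C=C/[C@@H]1C[C@@H](O)CC(=O)O1` share a core and differ only in the aryl group on the aromatic carbon. In an assay for inhibition of 3-hydroxy-3-methylglutaryl-coenzyme A reductase (Rattus norvegicus) (a higher number here means a weaker inhibitor, a lower number a stronger inhibitor), compound 1 gives 29 nM; in this assay compound 2 gives 36 nM. Among the compounds with values here, the only step measured so far, a 1.2-fold higher number from compound 1 to compound 2 (0.09 log units; within the scatter), stays within the scatter, so the two values show no order. Compound 2 stands at the higher of the two numbers, with compound 1 within the scatter of it.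

Compound 3 `COc1cccc(-c2cc(Cl)cc(Cl)c2/C=C/[C@@H]2C[C@@H](O)CC(=O)O2)c1` is not yet measured. The change from compound 2 is 3-methoxyphenyl in place of 4-fluoro-2-methylphenyl on an aromatic carbon. Within the data shown here, only one step bears on this position, the one from compound 1 to compound 2, and it was small; the methoxy group brings a hydrogen-bond acceptor that neither measured compound carries, for which no step exists. The expectation is therefore a step of a 1.3-fold higher number from compound 2 to compound 3 (0.10 log units; within the scatter) in this assay, with no clear direction beyond the scatter. Compound 3 is estimated at 45 nM, within 15 nM to 140 nM.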

Compound 3, half-maximal inhibitory concentration: 50 nM
Estimate against measurement, compound 3: 1.1-fold (0.05 log units) below; the range from low to high includes it.
By their numbers in this assay, from the lowest: compounds 1, 2 and 3 (each within the scatter of the next).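

In this assay the step of a 1.4-fold higher number from compound 2 to compound 3 (0.14 log units; within the scatter) and the step of a 1.7-fold higher number from compound 1 to compound 3 (0.24 log units; within the scatter) both leave the number within the scatter, so neither change at this position can be read as a shift in either direction. This extends the earlier result, which concerned only moving the methyl group of a fluorinated aryl group, to a different kind of substituent: 3-methoxyphenyl has no fluorine, has an oxygen and counts one hydrogen-bond acceptor, yet compounds 1, 2 and 3 remain within the scatter of the next in order. Nothing available on these compounds accounts for how close their numbers lie.

As far as these compounds go, all three aryl groups carry no net charge, so it remains open whether an amine or a carboxylic acid on this ring would take the number beyond the scatter. A longer alkoxy chain in place of the methoxy group is equally untested among the compounds shown.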